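The compounds below may be only part of what the source reports. "The series", "measured", "known", "first", "only" and "open" are said of these compounds alone.

Series notes. Compound 1 `COc1cc(C)nc2n/c(=N/C(=O)c3c(-c4ccc(Cl)cc4Cl)noc3C)sn12` and compound 2 `COc1cc(OC)n2s/c(=N\C(=O)c3c(-c4ccc(Cl)cc4Cl)noc3C)nc2n1` share one core; in a functional assay on the whole organism (strain L.) for inhibition, with Echinochloa crus-galli as the target, with a stated time of 72 h, tested at 100 mg/L (a lower number here means less inhibition of growth, a higher number more inhibition of growth at the concentration tested), compound 1 gives 80.5% and compound 2 gives 85.6%. For the measured compounds named here, the only change between them is methyl in place of methoxy on an aromatic carbon, and it makes a step of a number 5.1 percentage points lower from compound 2 to compound 1 (within the scatter). Compound 3 `COc1cc(OC)nc(NC(=S)NC(=O)c2c(-c3ccc(Cl)cc3Cl)noc2C)n1` has a different core; the difference between the two cores is not broken down here. In this assay compound 3 gives 60.9%, the lowest of the three, beyond the scatter from both others. Compound 4 `COc1cc(C)nc(NC(=S)NC(=O)c2c(-c3ccc(Cl)cc3Cl)noc2C)n1` is not yet measured. From compound 3 it differs by methyl in place of methoxy on an aromatic carbon; this is the same kind of change as from compound 2 to compound 1, but here the place is meta to a large group rather than part of a fused or bridged system of two rings, meta to a fused ring and para to a fused ring. For compound 4 the expected step is a number 2.9 percentage points lower from compound 3 to compound 4 (within the scatter), because a number 5.1 percentage points lower from compound 2 to compound 1 (within the scatter) lay within the scatter. Compound 4 is thus estimated at 58%, expected between 42% and 74%.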

Compound 4, percent growth inhibition at one concentration: 61.8%
Compound 4: the middle estimate sits 3.8 percentage points below what was measured; the range from low to high includes it.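

In this assay, methyl in place of methoxy makes a step of a number 0.9 percentage points higher from compound 3 to compound 4 (within the scatter), and the two cores show no difference in how they take this change: the same change on two cores in this assay, a number 5.1 percentage points lower (within the scatter) from compound 2 to compound 1 and a number 0.9 percentage points higher (within the scatter) from compound 3 to compound 4, 6 percentage points apart, within the scatter of two such steps. On these two pairs, the change therefore carries from one core to the other without moving the read-out beyond the scatter. This does not show that the two cores respond identically, as two pairs tested at one concentration cannot separate a small real effect from the scatter, and it says nothing about other cores.

The compounds shown leave open whether an amine, a chlorine or a longer chain such as ethoxy at this place would shift growth inhibition beyond the scatter.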